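Swapping the propargyl ether of compound 3 for an isopropyl ether

The source may hold more compounds than are shown below. What is called first, only, known or untested is meant among the compounds shown, and "the series" means these compounds.

Measured so far:
compound 1 `COC(=O)CSc1cc(/N=c2\sc(=S)n3n2CCCC3)c(F)cc1Cl`: 269 nM
compound 2 `S=c1n(-c2ccccc2)c(=S)n2n1CCCC2`: 3550 nM
compound 3 `C#CCOc1cc(/N=c2\sc(=S)n3n2CCCC3)c(F)cc1Cl`: 5.89 nM

In a functional assay on the whole organism for inhibition, with Echinochloa esculenta as the target (a higher number here means a weaker inhibitor, a lower number a stronger inhibitor), compound 3 gives the lowest of the three numbers, with compound 1 as its nearest neighbour (a 46-fold lower number from compound 1 to compound 3 (1.66 log units; beyond the scatter)). Compound 4 `CC(C)Oc1cc(/N=c2\sc(=S)n3n2CCCC3)c(F)cc1Cl` keeps that core and differs from compound 3 only as counted here: isopropyl in place of propargyl on an oxygen on an aromatic ring. For the measured compounds named here, no measured step exchanges one ether chain for another; the only step available, a 46-fold lower number from compound 1 to compound 3 (1.66 log units; beyond the scatter), changes a different group altogether and sets no direct expectation. With nothing closer to lean on, compound 4 is expected to stay in the range of compound 3 or lose some ground, giving an estimated 5.1-fold higher number from compound 3 to compound 4 (0.71 log units; beyond the scatter). Compound 4 is therefore estimated at 30 nM, between 6 nM and 150 nM.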

Compound 4, half-maximal inhibitory concentration: 28.2 nM
Estimate against measurement, compound 4: 1.1-fold (0.03 log units) above, and the stated range covers the measured number.
By their numbers in this assay, from the lowest: compound 3; then compound 4; then compound 1; then compound 2.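

In this assay isopropyl on this oxygen gives a 4.8-fold higher number from compound 3 to compound 4 (0.68 log units; beyond the scatter) and so keeps a low number without the triple bond, although the propargyl ether remains ahead. Isopropoxy also improves on the ((methoxycarbonyl)methyl)sulfanyl group, with a 9.5-fold lower number from compound 1 to compound 4 (0.98 log units; beyond the scatter) as its step, so the gain seen earlier does not belong to propargyloxy alone. Nothing available explains why these chains differ.

Still open, as far as these compounds go, is how a longer chain, such as butyl, or a ring, such as cyclopropylmethyl, would fare on this oxygen. An amine in place of the ether is equally untested by these compounds.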